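The source may hold more compounds than are shown below. What is called first, only, known or untested is meant among the compounds shown, and "the series" means these compounds.

In a functional assay on HCT-116 cells (Homo sapiens) for inhibition, read by CCK-8 assay, with a stated time of 72 h, tested at 2 uM (a higher number here means more inhibition of growth at the concentration tested, a lower number less inhibition of growth), two compounds have been measured so far. Compound 1 (`CCc1ccc(SCc2ccc(/C=C/C(=O)Nc3ccccc3N)cc2)cc1`) gives 3.29% and compound 2 (`Nc1ccccc1NC(=O)c1ccc(CSc2cccc(F)c2)cc1`) gives 5.5% in this test. These two values lie within the scatter of each other, so compound 2 stands level with compound 1, and both show little inhibition of growth.

Compound 3 (`Cc1cc(C)cc(SCc2ccc(C(=O)Nc3ccccc3N)cc2)c1`) differs from compound 2 in one place: it carries 3,5-dimethylphenyl in place of 3-fluorophenyl on a sulfur. For the measured compounds named here, no two measured compounds differ in just one place, so no measured step can serve as a guide. No shift beyond the scatter is therefore expected in this assay. The expected move (a number 2.5 percentage points higher from compound 2 to compound 3 (within the scatter)) is small, and its direction is uncertain. The estimated value for compound 3 is 8% with an expected range from 0% to 25% in repeated measurements.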

Compound 3, percent growth inhibition at one concentration: 3.22%
Estimate against measurement, compound 3: 4.8 percentage points above, within the range that was stated.
By their numbers in this assay, from the lowest: compounds 3, 1 and 2 (each within the scatter of the next).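

In this assay the exchange of 3-fluorophenyl for 3,5-dimethylphenyl on the sulfur gives a number 2.3 percentage points lower from compound 2 to compound 3 (within the scatter) and so leaves the two compounds level. For the compounds shown here, this is the first single change that can be read, and at this position a ring with a fluorine and a ring with two methyl groups cannot be told apart in this test. Both groups are six-membered aromatic rings of carbon only, with no hydrogen-bond donors or acceptors and no net charge, and no evidence is available on why the two compounds stand level.

The compounds shown leave open whether a group of a different kind on the sulfur, such as a ring carrying an amine or a carboxylic acid, would stand apart from these two. They also leave open whether any change at this position can lift growth inhibition beyond the scatter.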